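From Cyclopentyl to Furanyl on a Shared Core

The source may report more compounds than this note shows. Statements on the series, on what has been measured and on what is new or still open speak of the compounds shown alone.

Going by the values given here, compound 2 `COC(=O)c1nc(C2CCCC2)n(-c2ccc(F)cc2)n1` gives the lowest of the two numbers so far in a functional assay on NPC-TW01 cells (Homo sapiens) for inhibition, read by MTT assay, with a stated time of 72 h (on this read-out higher numbers stand for weaker inhibition of growth and lower numbers for stronger inhibition of growth), at 10400 nM. Its nearest neighbour is compound 1 `CCc1nc(C(=O)OC)nn1-c1ccc(F)cc1`, which in this assay gives 15800 nM; the step of a 1.5-fold lower number from compound 1 to compound 2 (0.18 log units; within the scatter) lies within the scatter, so the two cannot be ordered. Compound 3 `COC(=O)c1nc(-c2ccoc2)n(-c2ccc(F)cc2)n1` has not been measured. It differs from compound 2 by furan-3-yl in place of cyclopentyl on an aromatic carbon. The only measured step exchanged one saturated group for another and stayed within the scatter; no measured step replaces a saturated ring by an aromatic one, so nothing shown bears directly on the present change. On that basis a step of no more than the scatter is expected, a 1.0-fold lower number from compound 2 to compound 3 (0.02 log units; within the scatter), in either direction. Compound 3 is therefore estimated at 10000 nM in this assay, with a range from 3000 nM to 35000 nM.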

Compound 3, concentration for 50% growth inhibition: 11700 nM
Compound 3: the middle estimate sits 1.2-fold (0.07 log units) below what was measured, and the stated range covers the measured number.
By their numbers in this assay, from the lowest: compounds 2, 3 and 1 (each within the scatter of the next).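

At this aromatic carbon, furan-3-yl in place of cyclopentyl swaps a five-membered non-aromatic ring of carbon only for a five-membered aromatic ring with one hetero atom, and in this assay this gives a 1.1-fold higher number from compound 2 to compound 3 (0.05 log units; within the scatter) and leaves the two compounds unordered. Furan-3-yl in place of ethyl gives a 1.4-fold lower number from compound 1 to compound 3 (0.13 log units; within the scatter) and likewise stays within the scatter, so across the ethyl, cyclopentyl and furan-3-yl groups, the change of ring type and the added hydrogen-bond acceptor leave no step that can be told from repeat measurement. No evidence is available to explain this flat result.

From the compounds shown here alone, whether an amine, a carboxylic acid or a longer chain at this position would give a step beyond the scatter stays open. Going by these compounds, all three compounds share the methoxycarbonyl and 4-fluorophenyl groups, so the effect of changing either one is also open.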